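Swapping Acetyl for Dimethylamino on a Shared Core

The compounds below may be only part of what the source reports. "The series", "measured", "known", "first", "only" and "open" are said of these compounds alone.

Measured so far:
compound 1, `COc1cc(C)cc(-c2c(-c3ccnc(-c4ccc(C(C)=O)cc4)c3)cnn2CC#N)c1`: 71%
compound 2, `COc1cc(C)cc(-c2nn(CC#N)cc2-c2ccc(-c3cccc(C(C)=O)c3)nc2)c1`: 56%

In a functional assay on SW-620 cells (Homo sapiens) for cytotoxicity, read by sulforhodamine B assay, with a stated time of 48 h, tested at 100 nM (on this read-out lower numbers stand for a stronger effect and higher numbers for a weaker effect at the one concentration tested), compound 1 gives 71%, the higher of the two numbers. Compound 2 gives 56%, a gap beyond the usual scatter. Compound 3, `COc1cc(C)cc(-c2c(-c3ccnc(-c4ccc(N(C)C)cc4)c3)cnn2CC#N)c1`, differs from compound 1 by dimethylamino in place of acetyl on an aromatic carbon. Going by the values given here, no measured pair shows this change, so the direction is uncertain; the step of a number 5 percentage points lower from compound 1 to compound 3 (within the scatter) is expected to be modest, possibly within the scatter. Compound 3 is therefore estimated at 66%, within a range from 45% to 87%.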

Compound 3, a percentage reported as activity, at one concentration (the size of the read-out at that concentration, not a potency): 12%
For compound 3 the middle estimate is 54 percentage points above the measured one, outside the stated range (below it).
By their numbers in this assay, from the lowest: compound 3; then compound 2; then compound 1.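

In this assay, replacing 4-acetylphenyl with 4-(dimethylamino)phenyl gives a number 59 percentage points lower from compound 1 to compound 3 (beyond the scatter), so this place on the aromatic ring responds strongly to the identity of the group, and the change brings a stronger effect. The two groups match in heavy-atom count and hydrogen-bond acceptor count, so these counts do not separate them. Nothing available explains the step. On these data alone, whether a primary amine or a methoxy group at this place would act like dimethylamino remains open. So does whether the same swap would carry over to compound 2.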